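Swapping selenium for sulfur on the shared core of compound 1

This account rests on a few compounds, and the source may have more. Where it says the series, first, only, none or still open, it means among the compounds named here.

In a functional assay on MCF7 cells (Homo sapiens) for cytotoxicity, read by MTT assay, with a stated time of 72 h (on this read-out lower numbers stand for stronger inhibition of growth and higher numbers for weaker inhibition of growth), compound 1, with the structure `C[Se]/C(=N\C(=O)c1cc2ccccc2s1)NC(=O)c1cc2ccccc2s1`, gives 5070 nM, the lowest of the three numbers at hand. Compound 2, with the structure `CS/C(=N\C(=O)c1sccc1Cl)NC(=O)c1sccc1Cl`, gives 10300 nM in this assay, a step beyond the scatter. Compound 3, with the structure `CS/C(=N\C(=O)c1csc([N+](=O)[O-])c1)NC(=O)c1csc([N+](=O)[O-])c1`, gives 44700 nM in this assay, the furthest of the three from compound 1. Among the compounds with values here, compounds 2 and 3 carry methylsulfanyl on their central carbon and differ from compound 1 in their aromatic parts as well, so no step that changes only one place can be read from them.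

Compound 4, with the structure `CS/C(=N\C(=O)c1cc2ccccc2s1)NC(=O)c1cc2ccccc2s1`, is not yet measured. It differs from compound 1 by a group of 2 heavy atoms (1 carbon, 1 sulfur; no ring) in place of a group of 2 heavy atoms (1 carbon, 1 selenium; no ring), on a carbon with a double bond to nitrogen. Within the data shown here, no measured pair shows this change alone, so the direction is uncertain. The step from compound 1 to compound 4 is expected to be small, a 1.6-fold higher number from compound 1 to compound 4 (0.20 log units; within the scatter), toward a somewhat higher number. Compound 4 is estimated to give 8000 nM in this assay, within 3000 nM to 25000 nM.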

Compound 4, concentration for 50% growth inhibition: 9510 nM
Beside the measured number, compound 4's estimate is 1.2-fold (0.08 log units) below it, within the range that was stated.
By their numbers in this assay, from the lowest: compounds 1, 4 and 2 (each within the scatter of the next, the first and the last beyond it); then compound 3.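

Within the data shown here, compounds 1 and 4 give the first reading of this change on its own: on a carbon with a double bond to nitrogen whose other neighbours are amide-type nitrogens, methylsulfanyl replaces the group carrying selenium, and this assay shows a 1.9-fold higher number from compound 1 to compound 4 (0.27 log units; within the scatter). With the aromatic parts the same, selenium and sulfur at this place are therefore not told apart on this read-out, and the selenium atom is not shown to matter for growth inhibition here. Nothing measured on these compounds accounts for this result.

On these data alone, whether the same exchange would also leave the numbers within the scatter on the aromatic parts of compound 2 and compound 3 stays open. So does the outcome of placing an amine or a longer chain, such as ethylsulfanyl, on this carbon.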